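Trifluoromethoxy in place of trifluoromethyl: compound 3

The source may report more compounds than this note shows. Statements on the series, on what has been measured and on what is new or still open speak of the compounds shown alone.

Among the compounds with values here, compound 2 `O=C(Nc1c(C(O)(C(F)(F)F)C(F)(F)F)ccc2ccccc12)c1ccc(C(F)(F)F)cc1` gives the lowest of the two numbers measured so far: in an assay on LtK cells with ATP-sensitive inward rectifier potassium channel 11 (Homo sapiens) as the target (on this read-out lower numbers stand for an effect already at smaller amounts and higher numbers for an effect only at larger amounts of compound), compound 2 gives 160 nM, while compound 1 `Cc1ccccc1C(=O)Nc1c(C(O)(C(F)(F)F)C(F)(F)F)ccc2ccccc12` gives 5550 nM. Within the data shown here, the only measured step, a 35-fold lower number from compound 1 to compound 2 (1.54 log units; beyond the scatter), exchanges the whole aryl group on the carbonyl carbon and so bears only loosely on the next change. Compound 3 `O=C(Nc1c(C(O)(C(F)(F)F)C(F)(F)F)ccc2ccccc12)c1ccc(OC(F)(F)F)cc1` differs from compound 2 by trifluoromethoxy in place of trifluoromethyl on an aromatic carbon. Among the measured compounds shown here, no measured step isolates this exchange, so a change within the scatter, or at most a small one in either direction, is expected: a 1.3-fold higher number from compound 2 to compound 3 (0.10 log units; within the scatter). Compound 3 is estimated at 200 nM, with a range of 60 nM to 700 nM.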

Compound 3, half-maximal effective concentration: > 10000 nM
Compound 3: no number, only a limit (the forecaster's own chance of this, stated with the estimate: 3%); at least 50-fold (1.69 log units) between middle value and limit.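

At the position para to a large group, trifluoromethoxy in place of trifluoromethyl is far from a neutral exchange in this assay, with an at least 62-fold higher number from compound 2 to compound 3 (1.79 log units; beyond the scatter). Compound 3 stands at a limit and not at a number, so this step is only a floor: the limit of > 10000 nM in this assay, at which 1 of the 3 values shown sits. The other step, an at least 1.8-fold higher number from compound 1 to compound 3 (0.25 log units; that floor lies within the scatter), does not settle how far compound 3 lies from compound 1.

Open, on these data alone, is where compound 3 truly lies, and whether a nitrile, a methoxy group or a chlorine at this position stays near compound 2 or follows compound 3.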